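A few compounds are considered here, and "the series" means these few. Any claim that something is new, unique, unknown or untested is made for them only; others in the source may bear on it.

In a functional assay on A549 cells (Homo sapiens) for cytotoxicity, read by MTT assay, with a stated time of 24 h (on this read-out lower numbers stand for stronger inhibition and higher numbers for weaker inhibition), compound 1 (`C/C(=N\NC(=O)/C(C#N)=C/c1ccccc1)c1c(O)c2ccc(O)cc2oc1=O`) gives 14800 nM. In this assay, compound 2 (`C/C(=N\NC(=O)/C(C#N)=C/c1ccc([N+](=O)[O-])cc1)c1c(O)c2ccc(O)cc2oc1=O`) gives 9640 nM, a number within the usual scatter of compound 1, so the two cannot be told apart. Compound 3 (`C/C(=N\NC(=O)/C(C#N)=C/c1ccccc1Cl)c1c(O)c2ccc(O)cc2oc1=O`) has not yet been measured. It has 2-chlorophenyl in place of 4-nitrophenyl on a double-bonded chain carbon bound to a double-bonded chain carbon. Within the data shown here, only one measured step bears on this change: a 1.5-fold lower number from compound 1 to compound 2 (0.19 log units; within the scatter), which installed the nitro group that compound 3 lacks and stayed within the scatter. Among the measured compounds shown here, no measured compound carries a chlorine, so that half of the change is untested. No step beyond the scatter is therefore expected in this assay, in either direction. The estimated step is small: a 1.2-fold higher number from compound 2 to compound 3 (0.10 log units; within the scatter). The expected value for compound 3 is 12000 nM, within an estimated range of 6000 nM to 25000 nM.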

Compound 3, half-maximal inhibitory concentration: 14200 nM
Beside the measured number, compound 3's estimate is 1.2-fold (0.07 log units) below it; the range from low to high includes it.
By their numbers in this assay, from the lowest: compounds 2, 3 and 1 (each within the scatter of the next).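

In this assay, the exchange of 4-nitrophenyl for 2-chlorophenyl on a double-bonded chain carbon gives a 1.5-fold higher number from compound 2 to compound 3 (0.17 log units; within the scatter) and so cannot be told from no change. Adding the chlorine alone, which the earlier compounds did not test, gives a 1.0-fold lower number from compound 1 to compound 3 (0.02 log units; within the scatter) and stays equally small. Across compound 1, compound 2 and compound 3, this position has therefore carried a ring with no added group, with nitro or with chloro, and no step goes beyond the scatter. As far as these compounds go, whether an amine or a carboxylic acid on this ring, or a longer chain in its place, would produce a clear step stays open. No independent measurement is available here to explain why these three compounds read alike.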